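Chloro to Amino Swap on Two Related Cores

The source may report more compounds than this note shows. Statements on the series, on what has been measured and on what is new or still open speak of the compounds shown alone.

Compound 1 `Fc1ccc(Cn2cnc3c(Cl)ncnc32)cc1` and compound 3 `Nc1ncnc2c1ncn2Cc1ccc(F)cc1` share a core and differ in one group: amino in place of chloro on an aromatic carbon. In an assay on isolated protein for inhibition of RAC-alpha serine/threonine-protein kinase (Homo sapiens), tested at 30 uM (on this read-out lower numbers stand for less inhibition and higher numbers for more inhibition at the one concentration tested (going by the name of the read-out)), compound 1 gives 0% and compound 3 gives 0%; the step of no change at the digits printed from compound 1 to compound 3 (within the scatter). Compound 2 `Fc1ccc(Cn2cnc3ncnc(Cl)c32)cc1` is built from the same atoms as compound 1, joined differently; the difference between the two cores is not broken down here. In this assay compound 2 gives 0%, level with compounds 1 and 3 within the scatter. Compound 4 `Nc1ncnc2ncn(Cc3ccc(F)cc3)c12` stands to compound 2 as compound 3 stands to compound 1: amino in place of chloro on an aromatic carbon. Among the compounds with values here, this change occurs twice among the four compounds, and its only measured instance, from compound 1 to compound 3, left the read-out where it was. Because no change at the digits printed from compound 1 to compound 3 (within the scatter) shows no change, and because compound 2 gives 0%, the step of no change at the digits printed from compound 2 to compound 4 (within the scatter) is expected to be about as small. Compound 4 is therefore estimated at 0%, with a likely range from -5% to 10%.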

Compound 4, a percentage reported as inhibition, at one concentration (the size of the read-out at that concentration, not a potency): 0%
Estimate against measurement, compound 4: no gap at the digits printed; the range from low to high includes it.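

In this assay, putting amino in place of chloro on the core of compound 2 gives no change at the digits printed from compound 2 to compound 4 (within the scatter). Set beside the same change on the core of compound 1, the two steps agree: the same change on two cores in this assay, no change at the digits printed (within the scatter) from compound 1 to compound 3 and no change at the digits printed (within the scatter) from compound 2 to compound 4, 0 percentage points apart, within the scatter of two such steps. This agreement is thin evidence, though: the read-out stays flat across all four compounds, with compound 4 at 0%, so the change has carried over only among compounds that show no inhibition, and nothing here shows that it would stay as small on a compound that does inhibit this kinase.

As far as these compounds go, it remains open whether a different group in place of chloro, such as a methoxy group or a longer amine chain, would move the read-out away from where these four compounds sit. The compounds shown also leave open whether the two cores differ at all in this assay, as the values give no way to tell them apart.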